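Acetyl to ethoxycarbonyl on the compound 3 scaffold

A few compounds are considered here, and "the series" means these few. Any claim that something is new, unique, unknown or untested is made for them only; others in the source may bear on it.

- compound 1 `COc1ccc(/C=C(\C#N)C(=O)N/N=C(\C)c2cc3cccc(OC)c3oc2=O)cc1`: 3960 nM
- compound 2 `COc1ccc(/C=C(\C#N)C(=O)N/N=C(\C)c2cc3cccc(OC)c3oc2=O)cc1OC`: 8710 nM
- compound 3 `COc1cccc2cc(-c3ccc(C(C)=O)c(C)n3)c(=O)oc12`: 1240 nM
- compound 4 `CCOC(=O)c1ccc(-c2cc3cccc(OC)c3oc2=O)nc1C`: not yet measured

In a functional assay on K562 cells (Homo sapiens) for antiproliferative activity, read by MTT assay, with a stated time of 48 h (on this read-out lower numbers stand for stronger inhibition and higher numbers for weaker inhibition), compound 3 gives the lowest number of the three measured compounds, with both compound 1 and compound 2 clearly higher. Compound 4 differs from compound 3 by ethoxy in place of methyl on a carbonyl carbon, or acetyl to ethoxycarbonyl. Going by the values given here, no measured step covers this change. The only one available, a 2.2-fold higher number from compound 1 to compound 2 (0.34 log units; beyond the scatter), is a methoxy in place of hydrogen on an aromatic carbon, a different change in a different part of the structure, and it offers only a rough guide to how far one small substitution can move this series. A modest move is therefore expected in this assay, most likely towards a slightly higher number, though the direction is uncertain. The expected step is a 1.5-fold higher number from compound 3 to compound 4 (0.16 log units; within the scatter), which is not expected to lie clearly beyond the scatter. For compound 4 the estimated value is 1800 nM, with an expected range of 600 nM to 5500 nM.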

Compound 4, half-maximal inhibitory concentration: 8820 nM
For compound 4 the middle estimate is 4.9-fold (0.69 log units) below the measured one; the measured number lies above the stated range.
By their numbers in this assay, from the lowest: compound 3; then compound 1; then compounds 2 and 4 (each within the scatter of the next).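

In this assay, going by these compounds alone, acetyl to ethoxycarbonyl gives a 7.1-fold higher number from compound 3 to compound 4 (0.85 log units; beyond the scatter), the first sign that the group on this carbonyl carbon matters. The step lies beyond the scatter, so this position is not indifferent to the exchange: methyl, with 1 heavy atom, goes with the lower number, and ethoxy, with 3 heavy atoms and 1 hydrogen-bond acceptor, with the higher one. Nothing measured here accounts for the step.

The compounds shown leave open whether the higher number follows the added oxygen or the greater length of the group, a question that a methyl ester or a propyl ketone on the same carbonyl carbon would address. They also leave open how a carboxylic acid or an amide would read out at this position.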